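Dichlorophenyl Sulfonamide Tested Against an Inactive Ethylphenyl Parent

A few compounds are considered here, and "the series" means these few. Any claim that something is new, unique, unknown or untested is made for them only; others in the source may bear on it.

Compound 2 `CCc1ccc(S(=O)(=O)N2CCC(N3CCC(C)CC3)CC2)cc1` is a sulfonamide built on the shared core. In a functional assay on DLD-1 cells (Homo sapiens) for antiproliferative activity, read by CellTiter-Glo, with a stated time of 72 h (on this read-out lower numbers stand for stronger inhibition and higher numbers for weaker inhibition), compound 2 gives > 5000 nM, which is a limit of the assay and not a number. Its closest measured relative, compound 1 `CC1CCN(C2CCN(S(=O)(=O)c3ccc(C(C)(C)C)cc3)CC2)CC1`, carries tert-butyl where compound 2 carries ethyl on the aromatic carbon. In this assay compound 1 gives > 5000 nM, again a limit rather than a number. Among the measured compounds shown here, the step that the two limits leave unreadable from compound 1 to compound 2 is therefore unreadable, and the only thing the pair establishes is the limit of > 5000 nM in this assay, at which 2 of the 2 values shown sit.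

Compound 3 `CC1CCN(C2CCN(S(=O)(=O)c3cc(Cl)cc(Cl)c3)CC2)CC1` differs from compound 2 by 3,5-dichlorophenyl in place of 4-ethylphenyl on a sulfonyl sulfur. For the measured compounds named here, no measured step bears directly on this change, since the one step in the set cannot be sized. Compound 3 is expected to remain near the limit where compound 2 stands, so the step that the limit leaves unreadable from compound 2 to compound 3 is estimated to be small and most likely hidden behind the limit. The estimate for compound 3 is 8000 nM, with a range from 3000 nM to 30000 nM, and a high chance that only a limit is reported.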

Compound 3, half-maximal inhibitory concentration: 3400 nM
Estimate against measurement, compound 3: 2.4-fold (0.37 log units) above; measured number inside the range.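

Among the three compounds shown, only compound 3 gives a number rather than a limit in this assay, at 3400 nM, so this position on the sulfonyl sulfur can now be read on a measured scale for the first time. Setting 3,5-dichlorophenyl in place of 4-ethylphenyl gives an at least 1.4-fold lower number from compound 2 to compound 3 (0.16 log units; that floor lies within the scatter), and this floor is all the pair can state, so the change cannot yet be called a real gain, although the full step could be larger. The value for compound 2 is a limit and not a number, and the step between the two compounds that sit there cannot be read, which leaves the remaining comparison resting on a single boundary: the limit of > 5000 nM in this assay, at which 2 of the 3 values shown sit.

The compounds shown leave open whether a single chlorine on the aromatic ring would be enough to bring the read-out to a number, or whether both chlorines of compound 3 are needed. They also leave open what an amine, a carboxylic acid or a methoxy group on that aromatic ring would give in this assay.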